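This account rests on a few compounds, and the source may have more. Where it says the series, first, only, none or still open, it means among the compounds named here.

Measured so far in a functional assay on A549 cells (Homo sapiens) for cytotoxicity, read by XTT assay, with a stated time of 24 h; a higher number here means a weaker inhibitor, a lower number a stronger inhibitor:
- compound 1 `Cn1nnnc1SCC(=O)N/N=C/c1ccccc1`: 3160000 nM
- compound 2 `Cn1nnnc1SCC(=O)N/N=C/c1cccc(Cl)c1`: 7500000 nM

Compound 2 sits at the highest of the two numbers in this assay. Within the data shown here, the one measured step, a 2.4-fold higher number from compound 1 to compound 2 (0.38 log units; beyond the scatter), comes from placing chloro on the aromatic carbon and is modest but beyond the scatter.

Compound 3 `Cn1nnnc1SCC(=O)N/N=C/c1cccc(Br)c1` follows from compound 2 by bromo in place of chloro on an aromatic carbon, the position being on an aromatic carbon of a six-membered aromatic ring of carbon only, meta to a large group. Among the measured compounds shown here, no measured step swaps one halogen for another; the only step touching this position, from compound 1 to compound 2, was modest. The expected step of a 1.1-fold higher number from compound 2 to compound 3 (0.03 log units; within the scatter) is therefore small, most likely within the scatter, with any drift toward a higher number.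

For compound 3 in this assay the estimate is 8000000 nM, with a range from 3500000 nM to 18000000 nM.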

Compound 3, half-maximal inhibitory concentration: 600000 nM
The estimate for compound 3 lay 13-fold (1.12 log units) above the measured number; measured number below the stated range.
By their numbers in this assay, from the lowest: compound 3; then compound 1; then compound 2.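

Within this assay, the position on an aromatic carbon meta to a large group proves sensitive to which halogen it carries: the series shows a 13-fold lower number from compound 2 to compound 3 (1.10 log units; beyond the scatter) for bromo in place of chloro, a large step. Measured against hydrogen, the two halogens also part in direction: chloro gave a higher number, while bromo gives a 5.3-fold lower number from compound 1 to compound 3 (0.72 log units; beyond the scatter) in a modest step, so a single halogen no longer describes this position. No evidence at hand accounts for this difference between chloro and bromo.

Going by these compounds, whether iodo, fluoro, a methoxy group or an amine at this position would follow bromo or chloro remains open. The three compounds also leave open whether bromo would have the same effect at another carbon of the same ring.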